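Adding a nitro group to the hydrazone aryl ring

The compounds below may be only part of what the source reports. "The series", "measured", "known", "first", "only" and "open" are said of these compounds alone.

compound 1 `CC1=CC[C@H](C(C)(C)NC(=S)N/N=C/c2ccccc2)CC1`: 22200 nM
compound 2 `CC1=CC[C@H](C(C)(C)NC(=S)N/N=C/c2ccc(O)cc2)CC1`: > 100000 nM, a limit of the assay
compound 3 `CC1=CC[C@H](C(C)(C)NC(=S)N/N=C/c2ccccc2Cl)CC1`: > 100000 nM, a limit of the assay

Going by the values given here, in a functional assay on HT-29 cells (Homo sapiens) for inhibition, read by sulforhodamine B assay, with a stated time of 48 h (a higher number here means a weaker inhibitor of growth, a lower number a stronger inhibitor of growth), compound 1 gives 22200 nM, the only plain number among the three measured compounds. Compound 2 and compound 3 both sit at the limit of > 100000 nM in this assay, at which 2 of the 3 values shown sit. Compound 4 `CC1=CC[C@H](C(C)(C)NC(=S)N/N=C/c2cccc([N+](=O)[O-])c2)CC1` differs from compound 1 by nitro in place of hydrogen on an aromatic carbon. The two measured steps that add a group to the same ring, an at least 4.5-fold higher number from compound 1 to compound 2 (0.65 log units; beyond the scatter) and an at least 4.5-fold higher number from compound 1 to compound 3 (0.65 log units; beyond the scatter), both weakened growth inhibition to the point of a limit. A rise of similar kind is therefore expected, a 3.6-fold higher number from compound 1 to compound 4 (0.56 log units; beyond the scatter), possibly again reaching a limit. Compound 4 is estimated at 80000 nM, within a range of 20000 nM to 300000 nM.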

Compound 4, concentration for total growth inhibition: 21900 nM
Compound 4: the middle estimate sits 3.7-fold (0.56 log units) above what was measured; low and high end bracket the measured number.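

A nitro group on an aromatic carbon, meta to a large group, is tolerated, with a 1.0-fold lower number from compound 1 to compound 4 (0.01 log units; within the scatter). Adding a group to this ring therefore need not weaken growth inhibition, although compound 2 and compound 3 go against any wider claim of tolerance. Those two compounds remain limits of the assay, not numbers: the limit of > 100000 nM in this assay, at which 2 of the 4 values shown sit.

Hydroxy, chloro and nitro each appear at only one place on the ring, so the effect of the group cannot be separated from that of its position. An amine at the same place as the nitro group would help show whether this position accepts other groups.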